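Methoxy Added to the Phenyl Ring: What to Expect

The source may hold more compounds than are shown below. What is called first, only, known or untested is meant among the compounds shown, and "the series" means these compounds.

Compound 1 `COc1cc(/C=N/Nc2nc(-c3ccc(C(F)(F)F)cc3)cs2)c(Br)c(Br)c1OC` gives > 100000 nM in a functional assay on Caco-2 cells (Homo sapiens) for inhibition, read by MTT assay, with a stated time of 48 h (on this read-out higher numbers stand for weaker inhibition and lower numbers for stronger inhibition), which is a limit rather than a number.
Compound 2 `COc1cc(/C=N/Nc2nc(-c3ccccc3)cs2)c(Br)c(Br)c1OC` gives 26500 nM in this assay.
Compound 3 `COc1ccccc1-c1csc(N/N=C/c2cc(OC)c(OC)c(Br)c2Br)n1` has not yet been measured in this assay.

Compound 2 therefore holds the only true number among the results shown; the other result, for compound 1, is the limit of > 100000 nM in this assay, at which 1 of the 2 values shown sits. Within the data shown here, the single measured step, an at least 3.7-fold lower number from compound 1 to compound 2 (0.57 log units; beyond the scatter), shows that removing trifluoromethyl from the phenyl lowered the number by at least a modest amount.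

The change to compound 3 is methoxy in place of hydrogen on an aromatic carbon. Among the measured compounds shown here, no measured step tests a methoxy group, and the one step available concerns a different group at a different place on the phenyl, so it gives only indirect guidance. It suggests that a substituent on this phenyl did not help in the one case seen, which makes a small rise in the number, or no change beyond the scatter, the more likely outcome.

Compound 3 is expected to give 35000 nM, with a likely range from 12000 nM to 100000 nM. This corresponds to an expected step of a 1.3-fold higher number from compound 2 to compound 3 (0.12 log units; within the scatter).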

Compound 3, half-maximal inhibitory concentration: > 100000 nM
Compound 3 ended at the assay's limit; the forecaster's own chance of this, stated with the estimate: 25%; at least 2.8-fold (0.45 log units) between middle value and limit.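

Methoxy in place of hydrogen on this phenyl, ortho to a large group, gives an at least 3.7-fold higher number from compound 2 to compound 3 (0.57 log units; beyond the scatter) in this assay, which means weaker inhibition and is the first measured test of a methoxy group here. The earlier compounds shown here showed a cost only for trifluoromethyl, whereas this result shows a cost for a second, different group at a different place on the same phenyl, and the unsubstituted phenyl of compound 2 alone keeps a true number: the limit of > 100000 nM in this assay, at which 2 of the 3 values shown sit. Compound 1 and compound 3 both stand at limits, so the step between them cannot be read and the two groups cannot be ranked against each other.

As far as these compounds go, whether the loss belongs to methoxy itself or to its place remains open, and so does the outcome of methoxy elsewhere on this phenyl. From the compounds shown here alone, the result of a small group such as fluorine, or of an amine or a hydroxyl group, on the same aromatic carbon also remains unknown, which leaves it unclear whether any substituent on this phenyl can be tolerated.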